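A few compounds are considered here, and "the series" means these few. Any claim that something is new, unique, unknown or untested is made for them only; others in the source may bear on it.

Measured so far:
- compound 1, `Cc1cc(S(=O)(=O)/N=C(\N)n2nccc2-c2ccccc2)c(SCc2ccc(Cl)cc2)cc1Cl`: 0.34 h
- compound 2, `Cc1cc(-c2ccccc2)n(/C(N)=N/S(=O)(=O)c2cc(C)c(Cl)cc2SCc2ccc(C(F)(F)F)cc2)n1`: 0.241 h
- compound 3, `Cc1cc(-c2ccccc2)n(/C(N)=N/S(=O)(=O)c2cc(C)c(Cl)cc2SCc2ccccc2)n1`: 0.0938 h

In an ADME assay on microsomes from liver (Homo sapiens) for metabolic stability, read by LC-MS, using NADPH, tested at 5 uM (a higher number here means that the compound lasts longer, a lower number that the compound disappears faster), compound 3 gives 0.0938 h, the lowest half-life of the three; compound 2 stands nearest to it and compound 1 furthest, and both gaps lie beyond the scatter. Compound 4, `Cc1cc(-c2ccccc2)n(/C(N)=N/S(=O)(=O)c2cc(C)c(Cl)cc2SCc2ccc(Cl)cc2)n1`, has not yet been measured in this assay. It differs from compound 3 in one place: chloro in place of hydrogen on an aromatic carbon.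

Within the data shown here, one measured step bears directly on this change. Going a 2.6-fold lower number from compound 2 to compound 3 (0.41 log units; beyond the scatter), the number fell when the trifluoromethyl group was replaced by hydrogen at the same position. Compound 4 reverses the direction of that step by putting a chloro group where compound 3 carries hydrogen, so a modest rise in half-life is expected rather than a fall, though whether a chloro group recovers as much as the trifluoromethyl group did cannot be told from these data alone. Among the measured compounds shown here, compound 1 also carries a 4-chlorobenzyl group and shows the highest number here, but its core differs from that of compound 3 and no single step connects them.

Compound 4 is therefore expected to give 0.22 h in this assay, within a range from 0.1 h to 0.45 h. That estimate corresponds to an expected step of a 2.3-fold higher number from compound 3 to compound 4 (0.37 log units; beyond the scatter).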

Compound 4, half-life: 0.24 h
Beside the measured number, compound 4's estimate is 1.1-fold (0.04 log units) below it, and the stated range covers the measured number.
By their numbers in this assay, from the lowest: compound 3; then compounds 4, 2 and 1 (each within the scatter of the next).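

In this assay, chloro in place of hydrogen on the six-membered aromatic ring, para to a large group, gives a 2.6-fold higher number from compound 3 to compound 4 (0.41 log units; beyond the scatter), so the rise in half-life seen earlier with trifluoromethyl at this position also appears with a single chlorine atom. Exchanging one group for the other gives a 1.0-fold lower number from compound 2 to compound 4 (0.00 log units; within the scatter), which lies within the scatter, so these two groups cannot be told apart here, while each stands clear of hydrogen at this position. Among these compounds, the new compound also links compound 1 to this series for the first time: the methyl group on the core gives a 1.4-fold lower number from compound 1 to compound 4 (0.15 log units; within the scatter), likewise within the scatter, so in this 4-chlorobenzyl pair that methyl group has no readable effect on half-life.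

Nothing shown here explains why a group at this position changes the half-life. From the compounds shown here alone, it remains open whether a methoxy group, a fluorine atom or a nitrile on the same carbon would match chloro and trifluoromethyl, and whether a larger group such as a phenyl ring would extend the half-life beyond them.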